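This account rests on a few compounds, and the source may have more. Where it says the series, first, only, none or still open, it means among the compounds named here.

Measured compounds in an ADME assay on MT4 cells (Homo sapiens) for cytotoxicity, read by MTT assay, with a stated time of 5 days; a higher number here means that more compound is tolerated, a lower number that less compound is tolerated:
Compound 1 `Cc1cc(C)c(Oc2cc(Nc3ccc(C#N)cc3)ncc2C(=O)NCc2cn(CC(N)=O)nn2)c(C)c1` gives 24000 nM.
Compound 2 `Cc1cc(C)c(Oc2cc(Nc3ccc(C#N)cc3)ncc2C(=O)NCc2cn(Cc3ccccc3C#N)nn2)c(C)c1` gives only a limit of the assay, > 219000 nM.
Compound 3 `Cc1cc(C)c(Oc2cc(Nc3ccc(C#N)cc3)ncc2C(=O)NCc2cn(CC(=O)N3CCOCC3)nn2)c(C)c1` gives 181000 nM.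

Compound 1 stands lowest of the two numbers; its nearest neighbour is compound 3, a 7.5-fold higher number from compound 1 to compound 3 (0.88 log units; beyond the scatter). Compound 4 `Cc1cc(C)c(Oc2cc(Nc3ccc(C#N)cc3)ncc2C(=O)NCc2cn(Cc3ccccc3[N+](=O)[O-])nn2)c(C)c1` differs from compound 1 as follows: 2-nitrophenyl in place of carbamoyl on a saturated chain carbon bound to an aromatic nitrogen. The closest measured step is the change to compound 2 at the same place, an at least 9.1-fold higher number from compound 1 to compound 2 (0.96 log units; beyond the scatter), which ends at the limit (the limit of > 219000 nM in this assay, at which 1 of the 3 values shown sits). The change to compound 3 at a different place, a 7.5-fold higher number from compound 1 to compound 3 (0.88 log units; beyond the scatter), points the same way. For compound 4 a step of similar size is therefore expected, a 6.3-fold higher number from compound 1 to compound 4 (0.80 log units; beyond the scatter), with a fair chance that only a limit is returned. Compound 4 is estimated at 150000 nM, between 50000 nM and 300000 nM.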

Compound 4, half-maximal cytotoxic concentration: > 212000 nM
Compound 4: no number, only a limit; the forecaster's own chance of this, stated with the estimate: 50%; middle value at least 1.4-fold (0.15 log units) from the limit.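

In this assay, 2-nitrophenyl in place of carbamoyl at this place gives an at least 8.8-fold higher number from compound 1 to compound 4 (0.94 log units; beyond the scatter), the second aromatic group after 2-cyanophenyl to end far from the low number of the carbamoyl. Compound 4 returns only a limit, as does compound 2, so the step from nitrile to nitro cannot be read. The other new step, an at least 1.1-fold higher number from compound 3 to compound 4 (0.06 log units; that floor lies within the scatter), has a floor within the scatter and does not separate 2-nitrophenyl from (morpholin-4-yl)carbonyl.

Still open, going by these compounds, is whether an unsubstituted phenyl, an amine or a carboxylic acid at this place would stay with compound 3 or fall towards compound 1. On these data alone, the actual tolerated concentrations of compound 2 and compound 4 also remain unknown.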